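Swapping 4-ethylpiperazin-1-yl for piperidin-1-yl on compound 2

This account rests on a few compounds, and the source may have more. Where it says the series, first, only, none or still open, it means among the compounds named here.

In a functional assay on Jurkat cells (Homo sapiens) for inhibition, read by CCK-8 assay, with a stated time of 48 h (on this read-out lower numbers stand for stronger inhibition of growth and higher numbers for weaker inhibition of growth), compound 1 `Cc1ccc(Nc2ncc(Cl)c(Nc3ccccc3C)n2)cc1` gives > 100000 nM, which is a limit of the assay and not a number. Among the measured compounds shown here, compound 2 `CCN1CCN(c2ccc(Nc3ncc(Cl)c(Nc4ccccc4C)n3)cc2)CC1` gives 2060 nM, the only actual number so far, and so it has no other measured compound to be ranked against on a numerical scale. For the measured compounds named here, the one measured step is an at least 48-fold lower number from compound 1 to compound 2 (1.68 log units; beyond the scatter), made by placing 4-ethylpiperazin-1-yl where methyl stood on an aromatic carbon. Compound 1 fixes the size of that step only through (the limit of > 100000 nM in this assay, at which 1 of the 2 values shown sits), so the true step could be larger.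

Compound 3 `Cc1ccccc1Nc1nc(Nc2ccc(N3CCCCC3)cc2)ncc1Cl` keeps the shared core and changes that same group, with piperidin-1-yl in place of 4-ethylpiperazin-1-yl on an aromatic carbon. Going by the values given here, no measured step compares these two groups directly. Compound 2 nevertheless shows through an at least 48-fold lower number from compound 1 to compound 2 (1.68 log units; beyond the scatter) that this position can move the read-out strongly, so a moderate rise in this assay is expected rather than a return to the limit. The estimate means a 2.9-fold higher number from compound 2 to compound 3 (0.46 log units; beyond the scatter), an expected weakening of growth inhibition. For compound 3 the estimated value is 6000 nM, with an expected range of 1500 nM to 30000 nM.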

Compound 3, concentration for 50% growth inhibition: > 100000 nM
Compound 3 ended at the assay's limit; the forecaster's own chance of this, stated with the estimate: 10%; middle value at least 16-fold (1.22 log units) from the limit.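

Replacing 4-ethylpiperazin-1-yl with piperidin-1-yl on the aromatic carbon in this assay gives an at least 48-fold higher number from compound 2 to compound 3 (1.68 log units; beyond the scatter), so the growth inhibition gained earlier at this position is lost again. The earlier step showed only that 4-ethylpiperazin-1-yl does far better here than methyl, whereas this one shows that a six-membered non-aromatic ring at this place is not enough in itself, as the ring with 1 hetero atom falls away while the ring with 2 hetero atoms keeps a measurable value. The step from compound 1 to compound 3 cannot be read, and the size of the loss is only a lower bound, since the value of compound 3 is a limit of the assay and not a number: the limit of > 100000 nM in this assay, at which 2 of the 3 values shown sit.

Going by these compounds, what stays open is which part of 4-ethylpiperazin-1-yl carries the effect, the second ring nitrogen or the ethyl group on it. A piperazin-1-yl without the ethyl, a 4-methylpiperazin-1-yl or a morpholin-4-yl at this place would separate these, and a dimethylamino group would test whether a ring is needed at all.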